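A Hydroxy in Place of a Methyl on Compound 2

This account rests on a few compounds, and the source may have more. Where it says the series, first, only, none or still open, it means among the compounds named here.

Compound 1 `Cc1cc(NC(=O)Nc2cc(F)ccc2F)c2ccccc2n1`: 541 10^-6 cm/s
Compound 2 `Cc1ccc(NC(=O)Nc2cc(C)nc3ccccc23)cc1`: 669 10^-6 cm/s
Compound 3 `Cc1cc(NC(=O)Nc2cccc(C(N)=O)c2)c2ccccc2n1`: 2 10^-6 cm/s

In an ADME assay for permeability, using PAMPA, at pH 7.4 (on this read-out lower numbers stand for lower permeability and higher numbers for higher permeability), compound 2 gives the highest of the three numbers, 669 10^-6 cm/s. Compound 1 lies within the scatter of it, so no order between those two can be read, while compound 3 sits far lower, well beyond the scatter. Compound 4 `Cc1cc(NC(=O)Nc2ccc(O)cc2)c2ccccc2n1` is not yet measured; it differs from compound 2 by hydroxy in place of methyl on an aromatic carbon. For the measured compounds named here, no pair of measured compounds isolates this change, so the expectation rests on the wide spread the three compounds already show in this assay. A downward step beyond the scatter is expected, a 4.5-fold lower number from compound 2 to compound 4 (0.65 log units; beyond the scatter), smaller than the gap to compound 3. Compound 4 is therefore estimated at 150 10^-6 cm/s, in a range from 40 10^-6 cm/s to 500 10^-6 cm/s.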

Compound 4, apparent permeability: 3 10^-6 cm/s
Compound 4: middle estimate off by 50-fold (1.70 log units), on the high side, and the stated range ends above it.
By their numbers in this assay, from the lowest: compounds 3 and 4 (each within the scatter of the next); then compounds 1 and 2 (each within the scatter of the next).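

In this assay, for the compounds shown here, hydroxy in place of methyl on an aromatic carbon, para to a large group, gives a 220-fold lower number from compound 2 to compound 4 (2.35 log units; beyond the scatter) as the first step that isolates this change. The exchange of one heavy atom at this position, with a hydrogen-bond donor and a hydrogen-bond acceptor entering, is thus enough for a large step down. Nothing measured here accounts for the size of that step.

Going by these compounds, whether methoxy, an amine or a carboxylic acid at the same position would give a similar step remains open.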